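Chloro for methoxy on the benzoyl ring of compound 3

This account rests on a few compounds, and the source may have more. Where it says the series, first, only, none or still open, it means among the compounds named here.

Measured so far:
compound 1 `COc1ccc(-c2cc(C(=O)/C=C/c3ccc(Cl)cc3)nc3cc(-c4ccccc4)nn23)cc1OC`: 22000 nM
compound 2 `COc1ccc(-c2cc(/C=C/C(=O)c3ccc(C)cc3)nc3cc(-c4ccccc4)nn23)cc1OC`: 17200 nM
compound 3 `COc1ccc(C(=O)/C=C/c2cc(-c3ccc(OC)c(OC)c3)n3nc(-c4ccccc4)cc3n2)cc1`: 11900 nM

In a functional assay on A549 cells (Homo sapiens) for antiproliferative activity, read by MTT assay, with a stated time of 24 h (on this read-out lower numbers stand for stronger inhibition and higher numbers for weaker inhibition), compound 3 gives the lowest of the three numbers, yet the step from compound 2 to compound 3 is a 1.4-fold lower number from compound 2 to compound 3 (0.16 log units; within the scatter) and the step from compound 1 to compound 3 is a 1.8-fold lower number from compound 1 to compound 3 (0.27 log units; within the scatter), so no order among the three can be claimed. Compound 4 `COc1ccc(-c2cc(/C=C/C(=O)c3ccc(Cl)cc3)nc3cc(-c4ccccc4)nn23)cc1OC` differs from compound 3 by one change: chloro in place of methoxy on an aromatic carbon. For the measured compounds named here, the one measured step that bears directly on this is the swap at the same aromatic carbon from compound 2 to compound 3, a 1.4-fold lower number from compound 2 to compound 3 (0.16 log units; within the scatter), which stayed inside the scatter. The other two steps, a 1.3-fold lower number from compound 1 to compound 2 (0.11 log units; within the scatter) and a 1.8-fold lower number from compound 1 to compound 3 (0.27 log units; within the scatter), each involve a rearrangement of the linking chain together with a change of the ring substituent, and also stayed inside the scatter. Compound 4 is therefore expected to show a step of a 1.2-fold higher number from compound 3 to compound 4 (0.07 log units; within the scatter), that is, nothing beyond the scatter. For compound 4 the estimate in this assay is 14000 nM, with a range from 7000 nM to 28000 nM.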

Compound 4, half-maximal inhibitory concentration: 15400 nM
Estimate against measurement, compound 4: 1.1-fold (0.04 log units) below; measured number inside the range.
By their numbers in this assay, from the lowest: compounds 3, 4, 2 and 1 (each within the scatter of the next).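

Chloro in place of methoxy gives a 1.3-fold higher number from compound 3 to compound 4 (0.11 log units; within the scatter) in this assay, and chloro in place of methyl gives a 1.1-fold lower number from compound 2 to compound 4 (0.05 log units; within the scatter), so chloro, methoxy and methyl on this aromatic carbon now form a set of three in which no swap leaves the scatter. Reversing the chain can now be read on its own, with chloro on the ring at both ends of the comparison, and this gives a 1.4-fold lower number from compound 1 to compound 4 (0.15 log units; within the scatter) and also stays within the scatter. No supporting measurement accounts for these small steps.

From the compounds shown here alone, it remains open whether a group of another kind on this aromatic carbon, such as an amine or a carboxylic acid, would produce a step beyond the scatter. Whether a longer chain in place of the ethenyl link would do so is open as well.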